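From dichlorobenzyl to nitrobenzyl: an expected cytotoxicity value

A few compounds are considered here, and "the series" means these few. Any claim that something is new, unique, unknown or untested is made for them only; others in the source may bear on it.

Measured so far:
compound 1, `Cn1nc(-c2nnc(SCCOc3ccccc3F)o2)cc1-c1ccc(C(F)(F)F)cc1` — 25200 nM
compound 2, `Cn1nc(-c2nnc(SCc3ccc(Cl)c(Cl)c3)o2)cc1-c1ccc(C(F)(F)F)cc1` — 46200 nM

In a functional assay on Ehrlich cells (Mus musculus) for cytotoxicity, read by MTT assay, with a stated time of 24 h (on this read-out lower numbers stand for stronger inhibition and higher numbers for weaker inhibition), compound 1 gives 25200 nM and compound 2 gives 46200 nM. Going by the values given here, the one measured step, a 1.8-fold higher number from compound 1 to compound 2 (0.26 log units; within the scatter), replaced (2-fluorophenoxy)methyl with 3,4-dichlorophenyl on a saturated chain carbon bound to a sulfur. Among the compounds with values here, of the two numbers the one for compound 2 is the larger, but that step lies within the scatter, so the two compounds cannot be set apart on this read-out.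

Compound 3, `Cn1nc(-c2nnc(SCc3cccc([N+](=O)[O-])c3)o2)cc1-c1ccc(C(F)(F)F)cc1`, carries 3-nitrophenyl in place of 3,4-dichlorophenyl on a saturated chain carbon bound to a sulfur. The measured step concerns a different group at the same place and does not speak to a nitro group entering or chlorines leaving, so nothing measured bears directly on this change. Within the data shown here, with only one step in the set, and that one within the scatter, the expectation for compound 3 is a step of a 1.1-fold lower number from compound 2 to compound 3 (0.04 log units; within the scatter) in this assay, that is, no change beyond the scatter. Compound 3 is therefore estimated at 42000 nM, with a range from 15000 nM to 120000 nM.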

Compound 3, half-maximal inhibitory concentration: > 100000 nM
Compound 3: a limit, no number; the forecaster's own chance of this, stated with the estimate: 15%; middle value at least 2.3-fold (0.37 log units) from the limit.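

In this assay, the group on a saturated chain carbon bound to a sulfur now visibly matters: 3-nitrophenyl in place of 3,4-dichlorophenyl gives an at least 2.1-fold higher number from compound 2 to compound 3 (0.33 log units; beyond the scatter). Set against the (2-fluorophenoxy)methyl group at the same place, 3-nitrophenyl gives an at least 3.9-fold higher number from compound 1 to compound 3 (0.59 log units; beyond the scatter), so compound 3 is set apart from both earlier compounds, which the one earlier step, lying within the scatter, could not do for compound 1 and compound 2. The value of compound 3 is a limit and not a number, so these steps give only the least size of the change and how far the inhibition falls remains unknown: the limit of > 100000 nM in this assay, at which 1 of the 3 values shown sits.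

The compounds shown leave open whether the higher number goes with the nitro group entering or with the chlorines leaving, since both happen in the same step. A benzyl group carrying a single chlorine would separate those two changes, and an amine in place of the nitro group would show whether any other group at that spot on the ring gives a measurable number in this read-out.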